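The compounds below may be only part of what the source reports. "The series", "measured", "known", "first", "only" and "open" are said of these compounds alone.

Compound 1 `CCCCOc1ccc(-c2nc3ncccn3c2NC2CCCC2)cc1` stands second highest of the three numbers in a toxicity assay on A549 cells (Homo sapiens) for cytotoxicity, read by luminescence and CellTiter-Glo, with a stated time of 48 h (a higher number here means that more compound is tolerated, a lower number that less compound is tolerated), where compound 1 gives 40000 nM. Compound 2 `CCCCOc1ccc(-c2nc3ncccn3c2NCC2CCCCC2)cc1` gives 35000 nM, and compound 3 `CCCCOc1ccc(-c2nc3ncccn3c2Nc2ccccc2)cc1` gives 100000 nM. The step to compound 4 `CCCCOc1ccc(-c2nc3ncccn3c2NCc2ccc(OC)cc2)cc1` is 4-methoxybenzyl in place of cyclopentyl on a nitrogen on an aromatic ring. Going by the values given here, two measured steps bear on it: the aromatic ring entering recalls a 2.5-fold higher number from compound 1 to compound 3 (0.40 log units; beyond the scatter), while the extra carbon between the nitrogen and the ring recalls a 1.1-fold lower number from compound 1 to compound 2 (0.06 log units; within the scatter). Weighing both, a small upward step is expected, a 1.5-fold higher number from compound 1 to compound 4 (0.18 log units; within the scatter), likely at the edge of the scatter. Compound 4 is therefore estimated at 60000 nM, with a range from 25000 nM to 150000 nM.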

Compound 4, half-maximal cytotoxic concentration: 55000 nM
Beside the measured number, compound 4's estimate is 1.1-fold (0.04 log units) above it; the measured number falls inside the stated range.
By their numbers in this assay, from the lowest: compounds 2, 1, 4 and 3 (each within the scatter of the next, the first and the last beyond it).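

In this assay, 4-methoxybenzyl on the nitrogen brings an aromatic ring and a hydrogen-bond acceptor to this position, yet all three steps stay within the scatter: a 1.4-fold higher number from compound 1 to compound 4 (0.14 log units; within the scatter), a 1.6-fold higher number from compound 2 to compound 4 (0.20 log units; within the scatter) and a 1.8-fold lower number from compound 3 to compound 4 (0.26 log units; within the scatter). Compound 4 thus sits within the scatter of every earlier compound, although compound 3 lies beyond the scatter of compounds 1 and 2. Nothing available explains these numbers.

The compounds shown leave open how plain benzyl would read, and whether an amine or a carboxylic acid in place of the methoxy group would stay within the scatter.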